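The compounds below may be only part of what the source reports. "The series", "measured", "known", "first", "only" and "open" are said of these compounds alone.

Measured compounds and their values:
Compound 1 `C=CC(=O)Nc1cccc(Oc2nc(Nc3ccn(C)n3)nc3c2CSCC3)c1`: > 50000 nM
Compound 2 `C=CC(=O)Nc1cccc(Oc2nc(Nc3cccc(OC)c3)nc3c2CSCC3)c1`: > 50000 nM
Compound 3 `COc1cccc(Nc2nc3c(c(Oc4cccc(NC(=O)C=C(C)C)c4)n2)CSCC3)c1`: > 50000 nM

All three compounds were tested in a functional assay on MCF7 cells (Homo sapiens) for antiproliferative activity, read by MTT assay, with a stated time of 72 h (on this read-out lower numbers stand for stronger inhibition and higher numbers for weaker inhibition), and none gave an actual number: the limit of > 50000 nM in this assay, at which 3 of the 3 values shown sit. Compound 2 reads > 50000 nM, which is a limit of the assay and not a number.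

The next compound is compound 4 `C=CC(=O)Nc1cccc(Oc2nc(Nc3cccc(C#N)c3)nc3c2CSCC3)c1`, which differs from compound 2 in one place: cyano in place of methoxy on an aromatic carbon.

Going by the values given here, two measured steps bear on this change: a step that the two limits leave unreadable from compound 1 to compound 2 and a step that the two limits leave unreadable from compound 2 to compound 3. Among the compounds with values here, the first swaps the whole group on the nitrogen that carries the methoxy-bearing ring of compound 2, and the second alters the group on the carbonyl carbon. Neither has a readable size, so neither offers a size or a direction to carry over to this assay. Compound 4 is therefore expected to be reported as a limit again, since compound 2 came out of a step that the two limits leave unreadable from compound 1 to compound 2 still without a number.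

The estimate is a number no higher from compound 2 to compound 4 (the limit leaves the size open), with no direction expected. For compound 4 the expected value is 50000 nM, with an estimated range from 20000 nM to 100000 nM.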

Compound 4, half-maximal inhibitory concentration: 21700 nM
Beside the measured number, compound 4's estimate is 2.3-fold (0.36 log units) above it; the measured number falls inside the stated range.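

In this assay, compound 4 is the first compound shown to give an actual number, which makes the substituent on this aromatic carbon the first place where a change can be read, against a background where the other compounds stop at a limit: the limit of > 50000 nM in this assay, at which 3 of the 4 values shown sit.

Putting cyano in place of methoxy gives an at least 2.3-fold lower number from compound 2 to compound 4 (0.36 log units; beyond the scatter), and this size is only a floor, since the value for compound 2 is a limit and not a number. Going by these compounds alone, changing the whole group on the nitrogen, with 3-cyanophenyl in place of 1-methyl-1H-pyrazol-3-yl, gives an at least 2.3-fold lower number from compound 1 to compound 4 (0.36 log units; beyond the scatter), again a floor, whereas the earlier steps among compounds 1, 2 and 3 cannot be read at all.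

The compounds shown leave open whether another group on this aromatic carbon, such as an amine, a carboxylic acid or a chlorine atom, would lower the number further or lose it again. They also leave open whether cyano would give a number alongside the 2-methylprop-1-en-1-yl group of compound 3, so a single compound carries the finding for now.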